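The source may hold more compounds than are shown below. What is called first, only, known or untested is meant among the compounds shown, and "the series" means these compounds.

- Compound 1 `Cc1cc(N2CC[C@@H](C)[C@@H](N(C)c3ncnc4[nH]ccc34)C2)n2ncnc2n1`: 57900 nM
- Compound 2 `C=CCSc1nc2nc(C)cc(N3CC[C@@H](C)[C@@H](N(C)c4ncnc5[nH]ccc45)C3)n2n1`: > 100000 nM
- Compound 3 `Cc1cc(N2CC[C@@H](C)[C@@H](N(C)c3ncnc4[nH]ccc34)C2)n2nc(SCc3cc(Cl)ccc3Cl)nc2n1`: 87500 nM

All three values come from a toxicity assay on GES1 cells (Homo sapiens) for inhibition, read by MTT assay, with a stated time of 72 h; a lower number here means a stronger inhibitor, a higher number a weaker inhibitor. The entry for compound 2 is a limit of the assay, not a number. Compound 3 lies within the scatter of compound 1. Compound 4 `Cc1cc(N2CC[C@@H](C)[C@@H](N(C)c3ncnc4[nH]ccc34)C2)n2nc(SCCCc3ccccc3)nc2n1` carries phenethyl in place of 2,5-dichlorophenyl on a saturated chain carbon bound to a sulfur. Going by the values given here, three measured steps bear on this. Allylsulfanyl in place of hydrogen gave an at least 1.7-fold higher number from compound 1 to compound 2 (0.23 log units; that floor lies within the scatter), and (2,5-dichlorobenzyl)sulfanyl in place of hydrogen gave a 1.5-fold higher number from compound 1 to compound 3 (0.18 log units; within the scatter). The closest kind of change, 2,5-dichlorophenyl in place of vinyl, gave an at least 1.1-fold lower number from compound 2 to compound 3 (0.05 log units; that floor lies within the scatter). None of these steps stands clear of the scatter, so no step beyond it is expected in this assay. The expected step is a 1.2-fold lower number from compound 3 to compound 4 (0.07 log units; within the scatter). For compound 4 the estimated value is 75000 nM, with an expected range of 35000 nM to 140000 nM.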

Compound 4, half-maximal inhibitory concentration: > 100000 nM
Compound 4: no number, only a limit; the forecaster's own chance of this, stated with the estimate: 35%; middle value at least 1.3-fold (0.12 log units) from the limit.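

In this assay compound 4 gives > 100000 nM, a limit of the assay and not a number. On these data alone, its (3-phenylpropyl)sulfanyl group, which carries no chlorine, gives an at least 1.1-fold higher number from compound 3 to compound 4 (0.05 log units; that floor lies within the scatter) and an at least 1.7-fold higher number from compound 1 to compound 4 (0.23 log units; that floor lies within the scatter), so neither floor shows a step clear of the scatter, and the true size of either step remains unknown. The step between compound 2 and compound 4 cannot be read, and a second compound now sits at the ceiling: the limit of > 100000 nM in this assay, at which 2 of the 4 values shown sit.

As far as these compounds go, whether an amine or a carboxylic acid on this sulfanyl chain would give a clearly lower number in this assay remains open.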